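Swapping the benzylic aryl group on a sulfonamide-diamine scaffold

The compounds below may be only part of what the source reports. "The series", "measured", "known", "first", "only" and "open" are said of these compounds alone.

Three compounds sharing one core differ only in the aryl group on a saturated chain carbon bound to an amine nitrogen. Compound 1 `O=S(=O)(NCCCNCc1ccccc1Cl)c1cc(C(F)(F)F)cc(C(F)(F)F)c1` gives 15000 nM in a functional assay on PANC-1 cells (Homo sapiens) for inhibition, read by MTT assay, with a stated time of 72 h; a higher number here means a weaker inhibitor of growth, a lower number a stronger inhibitor of growth. Compound 2 `CC(C)(C)c1ccc(CNCCCNS(=O)(=O)c2cc(C(F)(F)F)cc(C(F)(F)F)c2)cc1` gives 2500 nM, and compound 3 `O=S(=O)(NCCCNCc1ccc(Cl)c(C(F)(F)F)c1)c1cc(C(F)(F)F)cc(C(F)(F)F)c1` gives 10000 nM; compound 3 thus sits second highest of the three. The changes at this position gave a 1.5-fold lower number from compound 1 to compound 3 (0.18 log units; within the scatter) and a 4.0-fold higher number from compound 2 to compound 3 (0.60 log units; beyond the scatter). Compound 4 `O=S(=O)(NCCCNCC1COc2ccccc2O1)c1cc(C(F)(F)F)cc(C(F)(F)F)c1` carries 2,3-dihydro-1,4-benzodioxin-2-yl in place of 4-chloro-3-(trifluoromethyl)phenyl on a saturated chain carbon bound to an amine nitrogen. Among the measured compounds shown here, no measured step involves a non-aromatic ring at this position, so the expected step of no change at the digits printed from compound 3 to compound 4 (within the scatter) is kept modest and uncertain. Compound 4 is therefore estimated at 10000 nM, with a range of 3000 nM to 30000 nM.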

Compound 4, concentration for 50% growth inhibition: 3400 nM
For compound 4 the middle estimate is 2.9-fold (0.47 log units) above the measured one, within the range that was stated.
By their numbers in this assay, from the lowest: compounds 2 and 4 (each within the scatter of the next); then compounds 3 and 1 (each within the scatter of the next).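

In this assay, a ring system with a non-aromatic ring works at this position: the 2,3-dihydro-1,4-benzodioxin-2-yl group gives a 2.9-fold lower number from compound 3 to compound 4 (0.47 log units; beyond the scatter) and a 4.4-fold lower number from compound 1 to compound 4 (0.64 log units; beyond the scatter). Against the 4-(tert-butyl)phenyl group it gives a 1.4-fold higher number from compound 2 to compound 4 (0.13 log units; within the scatter), so an aryl group on this carbon is not needed to match the best value shown. Nothing available explains these steps.

The compounds shown leave open whether the two ring oxygens matter. A cyclohexyl or a morpholine group at this position could test that.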